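This account rests on a few compounds, and the source may have more. Where it says the series, first, only, none or still open, it means among the compounds named here.

In a functional assay on KYSE-450 cells (Homo sapiens) for inhibition, read by CCK-8 assay, with a stated time of 48 h (a higher number here means a weaker inhibitor, a lower number a stronger inhibitor), compound 1 (`COc1ccc(CN(C(=O)CSC(=S)N2CCN(C(C)=O)CC2)c2cc(OC)c(OC)c(OC)c2)cc1`) gives 370 nM and compound 2 (`COc1ccc(CN(C(=O)CSC(=S)N2CCCc3cc(C)ccc32)c2cc(OC)c(OC)c(OC)c2)cc1`) gives 5210 nM as its half-maximal concentration. Compound 3 (`COc1cc(N(Cc2ccc(Br)cc2)C(=O)CSC(=S)N2CCN(C(=O)OC(C)(C)C)CC2)cc(OC)c1OC`) stands highest of the three at 10700 nM and is thus the weakest inhibitor measured so far. Compound 4 (`COc1ccc(CN(C(=O)CSC(=S)N2CCN(C(=O)OC(C)(C)C)CC2)c2cc(OC)c(OC)c(OC)c2)cc1Br`) carries 3-bromo-4-methoxyphenyl in place of 4-bromophenyl on a saturated chain carbon bound to an amide-type nitrogen. Among the measured compounds shown here, the only measured step (a 14-fold higher number from compound 1 to compound 2 (1.15 log units; beyond the scatter)) is large but lies on a thiocarbonyl carbon, so no measured step tests this place directly. Compound 2 (5210 nM) holds a methoxy-bearing group at this place, but it also differs from compound 3 elsewhere, so only a modest move toward a lower number is expected in this assay. The expected step is small to moderate (a 2.1-fold lower number from compound 3 to compound 4 (0.33 log units; beyond the scatter)) and remains uncertain. For compound 4 the estimated value is 5000 nM with an expected range from 1200 nM to 20000 nM as the likely span.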

Compound 4, half-maximal inhibitory concentration: 1850 nM
The estimate for compound 4 lay 2.7-fold (0.43 log units) above the measured number; the measured number falls inside the stated range.
By their numbers in this assay, from the lowest: compound 1; then compound 4; then compound 2; then compound 3.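

Among the compounds shown here, at the place on a saturated chain carbon bound to an amide-type nitrogen, which no earlier step had tested, this assay records a 5.8-fold lower number from compound 3 to compound 4 (0.76 log units; beyond the scatter) and so shows that the read-out responds to a change here. This step replaces 4-bromobenzyl with 3-bromo-4-methoxybenzyl, so the place of the bromine and the presence of a methoxy group change together, and the step alone cannot separate their shares. Nothing available accounts for the size of this step.

The compounds shown leave open whether 3-bromophenyl or 4-methoxyphenyl alone would give the same step, and how a ring bearing an amine or a carboxylic acid would read at this place. They also leave open whether 3-bromo-4-methoxyphenyl would lower the number to the same extent with the 4-acetylpiperazin-1-yl group of compound 1 on the thiocarbonyl carbon.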